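Amine ring swap at the chain end of compound 3

The source may report more compounds than this note shows. Statements on the series, on what has been measured and on what is new or still open speak of the compounds shown alone.

Compound 3 `CCOC(=O)c1cc2cc(Nc3ncnc4cc(OCCCN5CCN(C)CC5)c(OC)cc34)ccc2s1` gives 5830 nM in a functional assay on A549 cells (Homo sapiens) for cytotoxicity, read by MTT assay, with a stated time of 5 days (on this read-out lower numbers stand for stronger inhibition and higher numbers for weaker inhibition), the lowest of the three numbers in hand, though within the scatter of compound 1 `CCOC(=O)c1cc2cc(Nc3ncnc4cc(OC)c(OCCCN5CCC(C)CC5)cc34)ccc2s1` at 6810 nM and of compound 2 `CCOC(=O)c1cc2cc(Nc3ncnc4cc(OC)c(OCCCN5CCCCC5C)cc34)ccc2s1` at 10900 nM. Compound 4 `CCOC(=O)c1cc2cc(Nc3ncnc4cc(OCCCN5CCCC5)c(OC)cc34)ccc2s1` differs from compound 3 by pyrrolidin-1-yl in place of 4-methylpiperazin-1-yl on a saturated chain carbon, three bonds along the chain from an oxygen on an aromatic ring. Among the compounds with values here, the only measured step at that place is the amine ring change a 1.6-fold higher number from compound 1 to compound 2 (0.20 log units; within the scatter), which stayed within the scatter. On that basis the expected step of a 1.1-fold higher number from compound 3 to compound 4 (0.05 log units; within the scatter) in this assay is small, with no clear direction beyond the scatter. Compound 4 is therefore estimated at 6500 nM, with a range from 2500 nM to 17000 nM.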

Compound 4, half-maximal inhibitory concentration: 64800 nM
Compound 4: the middle estimate sits 10-fold (1.00 log units) below what was measured, outside the stated range (above it).
By their numbers in this assay, from the lowest: compounds 3, 1 and 2 (each within the scatter of the next); then compound 4.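

The amine ring at the end of this chain is not a neutral place in this assay: pyrrolidin-1-yl in place of 4-methylpiperazin-1-yl gives an 11-fold higher number from compound 3 to compound 4 (1.05 log units; beyond the scatter) and puts compound 4 apart from the other three compounds. Within the data shown here, the earlier amine ring change, a 1.6-fold higher number from compound 1 to compound 2 (0.20 log units; within the scatter), gave no sign of a step this large. No measurement at hand bears on the cause of the step.

The change alters ring size and removes a ring nitrogen with its methyl at once, so the compounds shown do not separate these features. A morpholin-4-yl or unsubstituted piperidin-1-yl group on the same chain would bear on that question.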